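Hydrazone aryl replacement on the shared core

A few compounds are considered here, and "the series" means these few. Any claim that something is new, unique, unknown or untested is made for them only; others in the source may bear on it.

Measured compounds:
compound 1 `O=C(N/N=C/c1ccccc1)Nc1ccc(Oc2ccnc3[nH]ccc23)c(F)c1` — 2500 nM
compound 2 `COc1cc(/C=N/NC(=O)Nc2ccc(Oc3ccnc4[nH]ccc34)c(F)c2)cc(OC)c1OC` — 34100 nM
compound 3 `O=C(N/N=C/c1ccccc1)Nc1ccc(Oc2ccnc3[nH]ccc23)cc1` — 17200 nM

In a functional assay on A549 cells (Homo sapiens) for antiproliferative activity, read by MTT assay, with a stated time of 72 h (on this read-out lower numbers stand for stronger inhibition and higher numbers for weaker inhibition), compound 3 stands second highest of the three numbers, within the scatter of compound 2 and well above compound 1, as a 6.9-fold higher number from compound 1 to compound 3 (0.84 log units; beyond the scatter) shows. Compound 4 `CN(C)CCn1cccc1/C=N/NC(=O)Nc1ccc(Oc2ccnc3[nH]ccc23)cc1` differs from compound 3 by 1-(2-(dimethylamino)ethyl)-1H-pyrrol-2-yl in place of phenyl on a carbon with a double bond to nitrogen. For the measured compounds named here, no measured step alters the group on the carbon with a double bond to nitrogen in a single change; compound 2 gives a higher number than compound 1 after a change at that end, but the two differ in several places, so this bears only loosely. Compound 4 is therefore expected near compound 3, with a 1.1-fold lower number from compound 3 to compound 4 (0.06 log units; within the scatter), estimated at 15000 nM (range 4000 nM to 60000 nM).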

Compound 4, half-maximal inhibitory concentration: "not active" (no number reported)
For compound 4 the study gives words and no number; no gap can be computed for the estimate.
By their numbers in this assay, from the lowest: compound 1; then compounds 3 and 2 (each within the scatter of the next).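

For the compounds shown here, compound 4 is reported in words without a number, so no step from compound 3 to compound 4 can be read. No evidence at hand bears on this result. The compounds shown leave open how 1-(2-(dimethylamino)ethyl)-1H-pyrrol-2-yl compares numerically with phenyl on the shared core.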